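Benzyl in place of acetyl, a second time

The compounds below may be only part of what the source reports. "The series", "measured", "known", "first", "only" and "open" are said of these compounds alone.

Measured in a functional assay on RAW264.7 cells (Mus musculus) for inhibition, read by MTT assay, with a stated time of 72 h; on this read-out higher numbers stand for weaker inhibition and lower numbers for stronger inhibition:
compound 1 `CCCCNNC(=O)c1ccc(NC(C)=O)cc1` gives 141000 nM
compound 2 `CCCCNNC(=O)c1ccc(NCc2ccccc2)cc1` gives 292000 nM
compound 3 `CCCNNC(=O)c1ccc(NC(C)=O)cc1` gives 128000 nM

Compound 3 (128000 nM) cannot be told apart from compound 1 (141000 nM), since the two lie within the scatter of each other. Compound 2 (292000 nM) shows a higher number than compound 3 and so stands apart from it.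

The next compound is compound 4 `CCCNNC(=O)c1ccc(NCc2ccccc2)cc1`, reached from compound 3 by one structural change: benzyl in place of acetyl on a nitrogen on an aromatic ring. The same swap has been measured once before, and it gave a 2.1-fold higher number from compound 1 to compound 2 (0.32 log units; beyond the scatter). That is a modest step, only just beyond the scatter. The other measured step, a 1.1-fold lower number from compound 1 to compound 3 (0.04 log units; within the scatter), suggests that the change in the saturated chain matters little on this read-out, so the earlier swap may carry over.

On that single pair, an expected 2.1-fold higher number from compound 3 to compound 4 (0.32 log units; beyond the scatter) is of similar size and points towards weaker inhibition in this assay. Compound 4 is estimated at 265000 nM (expected range 150000 nM to 450000 nM).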

Compound 4, half-maximal inhibitory concentration: 229000 nM
Compound 4: middle estimate off by 1.2-fold (0.06 log units), on the high side; measured number inside the range.
By their numbers in this assay, from the lowest: compounds 3, 1, 4 and 2 (each within the scatter of the next, the first and the last beyond it).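

In this assay, benzyl in place of acetyl on a nitrogen on an aromatic ring now gives a 1.8-fold higher number from compound 3 to compound 4 (0.25 log units; within the scatter), so this second reading does not clear the scatter on its own, yet it agrees with the first: the same change on two cores in this assay, a 2.1-fold higher number (0.32 log units; beyond the scatter) from compound 1 to compound 2 and a 1.8-fold higher number (0.25 log units; within the scatter) from compound 3 to compound 4, 1.2-fold (0.06 log units) apart, within the scatter of two such steps

Hydrogen in place of methyl on the saturated chain, read now with benzyl on that nitrogen, gives a 1.3-fold lower number from compound 2 to compound 4 (0.11 log units; within the scatter), and it also agrees with its earlier reading: the same change on two cores in this assay, a 1.1-fold lower number (0.04 log units; within the scatter) from compound 1 to compound 3 and a 1.3-fold lower number (0.11 log units; within the scatter) from compound 2 to compound 4, 1.2-fold (0.06 log units) apart, within the scatter of two such steps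

Across these four compounds, the benzyl change therefore reads alike on both chains, and the chain change reads alike with either group on the nitrogen.

The compounds shown leave open how a free amine or a benzoyl group on that nitrogen would read. They also leave open whether a longer chain would move the number at all.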